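This account rests on a few compounds, and the source may have more. Where it says the series, first, only, none or still open, it means among the compounds named here.

Measured so far:
compound 1 `COc1cc(-c2nn(-c3cccc(NC(=O)c4cccc(C(F)(F)F)c4)c3)cc2-c2ccncc2)ccc1Cl` — > 50000 nM
compound 2 `O=C(Nc1cccc(-n2cc(-c3ccncc3)c(-c3ccc(Cl)c(O)c3)n2)c1)Nc1cc(C(F)(F)F)cc(C(F)(F)F)c1` — 17400 nM

In a functional assay on DU-145 cells (Homo sapiens) for inhibition, read by sulforhodamine B assay, with a stated time of 48 h (on this read-out lower numbers stand for higher toxicity in this test and higher numbers for lower toxicity in this test), compound 1 reports only a limit, > 50000 nM, and no number, as the evidence shows (the limit of > 50000 nM in this assay, at which 1 of the 2 values shown sits). In this assay compound 2 gives 17400 nM. Compound 3 `COc1cc(-c2nn(-c3cccc(NC(=O)c4ccccc4)c3)cc2-c2ccncc2)ccc1Cl` differs from compound 1 by hydrogen in place of trifluoromethyl on an aromatic carbon. Among the compounds with values here, no measured pair carries this change, so the step is expected to stay within the usual scatter, with no direction beyond it, a step that the limit leaves unreadable from compound 1 to compound 3. Compound 3 is therefore expected at about 60000 nM, within a range of 20000 nM to 200000 nM, and most likely again reported only as a limit.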

Compound 3, concentration lethal to 50% of the cells: > 100000 nM
Compound 3 was reported as a limit; the forecaster's own chance of this, stated with the estimate: 65%; middle value at least 1.6-fold (0.22 log units) away from the limit.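

Compound 1 stands only as a limit, > 50000 nM. Within the data shown here, compound 3 is also only a limit, > 100000 nM, so no step between it and compound 1 can be read. As far as these compounds go, the size and direction of any effect of hydrogen in place of trifluoromethyl on an aromatic carbon in this assay remain open.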